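From 3-chlorophenyl to 4-ethylphenyl on the sulfonyl sulfur

A few compounds are considered here, and "the series" means these few. Any claim that something is new, unique, unknown or untested is made for them only; others in the source may bear on it.

Compound 1 `O=S(=O)(Nc1ccc(-c2nc3ccccc3o2)cc1)c1cccc(Cl)c1` is the starting point. In an ADME assay on HEK293 cells (Homo sapiens) for cytotoxicity, read by resazurin assay, with a stated time of 48 h (on this read-out lower numbers stand for higher toxicity in this test and higher numbers for lower toxicity in this test), compound 1 gives > 100000 nM as a limit and not a number. Compound 1 thus sits at the limit of > 100000 nM in this assay, at which 2 of the 3 values shown sit, and has no exact figure. Compound 3 `O=S(=O)(Nc1ccc(-c2nc3ccccc3o2)cc1)c1cccc(C(F)(F)F)c1` gives > 100000 nM as a limit too. Among the compounds with values here, compound 2 `O=S(=O)(Nc1ccc2oc(-c3ccccc3)nc2c1)c1ccc(Cl)cc1` gives 65000 nM as a measured number, but no single-change step links it to compound 1, so it sets no size for the change considered here.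

Compound 4 `CCc1ccc(S(=O)(=O)Nc2ccc(-c3nc4ccccc4o3)cc2)cc1` carries 4-ethylphenyl in place of 3-chlorophenyl on a sulfonyl sulfur and is not yet measured. Within the data shown here, the one measured step that bears on this change is a step that the two limits leave unreadable from compound 1 to compound 3 and it offers no size to carry over. It does show that another change in this group left the compound at the same limit. On that thin basis, no step beyond the scatter is expected in this assay and no direction is favoured. The expected step is a number no higher from compound 1 to compound 4 (the limit leaves the size open) on this reading. Compound 4 is estimated at 100000 nM with an expected range from 50000 nM to 200000 nM and a limit is the likeliest expected outcome.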

Compound 4, half-maximal cytotoxic concentration: 82000 nM
Beside the measured number, compound 4's estimate is 1.2-fold (0.09 log units) above it, and the stated range covers the measured number.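

With 4-ethylphenyl on the sulfonyl sulfur, compound 4 gives the first exact figure for a change on this group of the core of compound 1 in this assay, whereas the step from compound 1 to compound 3 cannot be read. The new step is an at least 1.2-fold lower number from compound 1 to compound 4 (0.08 log units; that floor lies within the scatter), so it sets a floor and not a size, and it does not establish that this change moves the number by more than repeated measurements would. It does show that a change at this position can give a measured number and not a limit, which matters in a set whose upper end remains crowded: the limit of > 100000 nM in this assay, at which 2 of the 4 values shown sit.

The compounds shown leave open whether the ethyl group or its place on the ring goes with this reading, as 4-ethylphenyl replaces 3-chlorophenyl in a single step and both features differ at once. Also open, as far as these compounds go, is how an amine, a carboxylic acid or a longer chain on this ring would read in this assay, and whether any such group would lower the number beyond the scatter.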